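The source may hold more compounds than are shown below. What is called first, only, known or untested is meant among the compounds shown, and "the series" means these compounds.

Measured compounds in a physicochemical assay for solubility, in phosphate buffer, measured as kinetic solubility, at pH 7.4; a lower number here means a less soluble compound, a higher number a more soluble compound:
compound 1 `Cc1oc(-c2ccccc2Cl)nc1CN1CCC(C(=O)NCCCN2C[C@H](C)C[C@H](C)C2)CC1`: > 72 ug/mL
compound 2 `Cc1oc(-c2c(Cl)cccc2Cl)nc1CN1CCC(C(=O)NCCCN2C[C@H](C)C[C@H](C)C2)CC1`: > 77 ug/mL
compound 3 `Cc1ccc(-c2nc(CN3CCC(C(=O)NCCCN4C[C@H](C)C[C@H](C)C4)CC3)c(C)o2)cc1`: > 69 ug/mL

Compound 3 stands at a limit of this assay: its value of > 69 ug/mL is not a number. Compound 1 also reports only a limit, > 72 ug/mL. Compound 2 likewise reports only a limit, > 77 ug/mL. Compound 4 `COc1cccc(C)c1-c1nc(CN2CCC(C(=O)NCCCN3C[C@H](C)C[C@H](C)C3)CC2)c(C)o1` differs from compound 3 in one place: 2-methoxy-6-methylphenyl in place of 4-methylphenyl on an aromatic carbon. The steps that touch this position, a step that the two limits leave unreadable from compound 1 to compound 3 and a step that the two limits leave unreadable from compound 2 to compound 3, have no readable size because of the limit of > 69 ug/mL in this assay, at which 1 of the 3 values shown sits, the limit of > 72 ug/mL in this assay, at which 1 of the 3 values shown sits, and the limit of > 77 ug/mL in this assay, at which 1 of the 3 values shown sits, hide both ends of each step. Among the compounds with values here, no measured step therefore sets a direction, and the expected step that the limit leaves unreadable from compound 3 to compound 4 is none beyond the scatter. Compound 4 is expected to give 70 ug/mL, with a range from 30 ug/mL to 110 ug/mL.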

Compound 4, solubility: > 73 ug/mL
Compound 4 ended at the assay's limit (the forecaster's own chance of this, stated with the estimate: 60%); middle value at least 1.0-fold (0.01 log units) from the limit.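

In this assay compound 4 gives > 73 ug/mL, a limit and not a number. Its steps from compound 1, compound 2 and compound 3, which also report limits, cannot be read. The compounds shown leave open whether their different phenyl groups separate at all in this assay.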